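Configuration change at the ring carbon of compound 2

A few compounds are considered here, and "the series" means these few. Any claim that something is new, unique, unknown or untested is made for them only; others in the source may bear on it.

Among the compounds with values here, compound 1 `Cc1ccc([C@]2(C)CC[C@@H]3C[C@@]32C)cc1O` and compound 2 `Cc1ccc([C@]2(C)CC[C@H](C(C)(C)O)O2)cc1` are the two members measured so far. In a functional assay on BGC-823 cells (Homo sapiens) for cytotoxicity, read by MTT assay (on this read-out lower numbers stand for stronger inhibition and higher numbers for weaker inhibition), compound 1 gives only the limit > 10 ug/mL. In this assay compound 2 likewise gives only the limit > 10 ug/mL. Compound 2 therefore stands at the limit of > 10 ug/mL in this assay, at which 2 of the 2 values shown sit, without a number of its own. Compound 3 `Cc1ccc([C@]2(C)CC[C@@H](C(C)(C)O)O2)cc1` is the untested partner: the two compounds have the same atoms and bonds and differ only in configuration as drawn: 1 of 2 stereo elements differ; a stereocentre at a saturated ring carbon is drawn R in compound 2 and S in compound 3. Within the data shown here, no measured step between compounds exists, so in this assay no step beyond the scatter is expected. Compound 3 is expected to give 15 ug/mL in this assay, estimated between 8 ug/mL and 50 ug/mL, most probably again as a limit. The expected step that the limit leaves unreadable from compound 2 to compound 3 is essentially none.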

Compound 3, half-maximal inhibitory concentration: > 10 ug/mL
Compound 3: only a limit was reported; the forecaster's own chance of this, stated with the estimate: 85%; the middle value does not contradict the limit.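

Within the data shown here, compound 2 and compound 3 both give only a limit in this assay; no step between them can be read. The compounds shown leave open whether the configuration at this ring carbon matters for the read-out at all.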